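A few compounds are considered here, and "the series" means these few. Any claim that something is new, unique, unknown or untested is made for them only; others in the source may bear on it.

In a functional assay on MDA-MB-231 cells (Homo sapiens) for antiproliferative activity, with a stated time of 4 days (a higher number here means a weaker inhibitor, a lower number a stronger inhibitor), compound 1 (`COc1ccc(-c2[nH]c3ccc(OC)cc3c2C=O)cc1`) gives 260 nM and compound 2 (`COc1ccc(-c2[nH]c3ccc(F)cc3c2C=C(C#N)C#N)cc1`) gives 400 nM, two values within the scatter of each other. Compound 3 (`COc1ccc(-c2[nH]c3ccc(C(C)C)cc3c2C=C(C#N)C#N)cc1`) has isopropyl in place of fluoro on an aromatic carbon. Within the data shown here, no measured pair shows a change at this place, so the expectation rests on the structural change alone. The expected 1.8-fold higher number from compound 2 to compound 3 (0.24 log units; within the scatter) is a small one in this assay, towards a higher number and so a weaker inhibitor. For compound 3 the estimated value is 700 nM, with an expected range of 200 nM to 2500 nM.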

Compound 3, half-maximal inhibitory concentration: 210 nM
Compound 3: the middle estimate sits 3.3-fold (0.52 log units) above what was measured; low and high end bracket the measured number.
By their numbers in this assay, from the lowest: compounds 3, 1 and 2 (each within the scatter of the next).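

Isopropyl in place of fluoro gives the first step that can be read at this aromatic carbon: in this assay the step is a 1.9-fold lower number from compound 2 to compound 3 (0.28 log units; within the scatter) and does not separate the two groups. This place therefore carries either group with no difference beyond the scatter, a point the earlier values could not show. No measurement on hand accounts for this result. Still open, from the compounds shown here alone, is whether an amine or a carboxylic acid on this aromatic carbon, or a chain longer than isopropyl, would stay within the same range.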